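From compound 3 to compound 4: the amide-type nitrogen

The source may hold more compounds than are shown below. What is called first, only, known or untested is meant among the compounds shown, and "the series" means these compounds.

In a functional assay on GBM1 cells (Homo sapiens) for antiproliferative activity, read by WST assay, with a stated time of 72 h (a lower number here means a stronger inhibitor, a higher number a weaker inhibitor), compound 1 (`O=C(Nc1cccc(Cl)c1)Nc1cc2ncncc2cc1OCc1ccccc1Cl`) gives 2600 nM, compound 3 (`O=C(Nc1cccc(Cl)c1)Nc1cc2ncncc2cc1OCc1cccc(Cl)c1`) gives 3300 nM and compound 2 (`O=C(Nc1cc2ncncc2cc1OCc1ccc(F)cc1)Nc1cccc2ccccc12`) gives 8100 nM. Compound 3 thus lies within the scatter of compound 1, while the number for compound 2 is higher than that for compound 3 by more than the scatter.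

Compound 4 (`O=C(Nc1ccccc1F)Nc1cc2ncncc2cc1OCc1cccc(Cl)c1`) carries 2-fluorophenyl in place of 3-chlorophenyl on an amide-type nitrogen.

For the measured compounds named here, the only measured single-place step, a 1.3-fold higher number from compound 1 to compound 3 (0.10 log units; within the scatter), concerns a group on a saturated chain carbon and stays within the scatter. Going by the values given here, no measured step changes the group on the amide-type nitrogen, so the guidance is weak. Compound 2 has a different group there but also differs elsewhere, so it cannot isolate this change.

The estimated step is a 1.2-fold higher number from compound 3 to compound 4 (0.08 log units; within the scatter), and no change beyond the scatter is expected in this assay. For compound 4 the estimate is 4000 nM, with an expected range from 1800 nM to 9500 nM.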

Compound 4, half-maximal inhibitory concentration: 4200 nM
The estimate for compound 4 lay 1.1-fold (0.02 log units) below the measured number; measured number inside the range.
By their numbers in this assay, from the lowest: compounds 1, 3, 4 and 2 (each within the scatter of the next, the first and the last beyond it).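

In this assay, for the compounds shown here, replacing 3-chlorophenyl with 2-fluorophenyl on the amide-type nitrogen gives a 1.3-fold higher number from compound 3 to compound 4 (0.10 log units; within the scatter) and provides the first single-place reading at this position. The earlier step concerned only the group on the saturated chain carbon, whereas this pair shows that one exchange of aryl groups with equal heavy-atom counts on the nitrogen stays within the scatter. No measurement bearing on the reason for this outcome is available.

The halogen and its ring position differ together in this pair, so their separate contributions cannot be read, and compound 2 cannot isolate the nitrogen group because it also differs on the saturated chain carbon. The compounds shown leave open how this nitrogen would respond to a phenyl carrying an amine or a carboxylic acid, or to a longer chain in place of the aromatic ring.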